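The compounds below may be only part of what the source reports. "The series", "measured", "known", "first", "only" and "open" are said of these compounds alone.

Measured compounds:
- compound 1, `ClCc1ccc(Cn2cnc3nc(Cl)nc(Cl)c32)cc1`: 4070 nM
- compound 2, `ClCc1ccc(Cn2cnc3c(Cl)nc(Cl)nc32)cc1`: 37200 nM

Of the compounds shown here, two have been measured in a functional assay on A549 cells (Homo sapiens) for cytotoxicity, read by sulforhodamine B assay, with a stated time of 48 h; on this read-out higher numbers stand for weaker inhibition of growth and lower numbers for stronger inhibition of growth. Compound 1 gives 4070 nM and stands at the lowest number of the two; compound 2 gives 37200 nM, a higher number that lies beyond the scatter of the method. For the measured compounds named here, the two share the chloromethyl-substituted benzyl arm but differ in the arrangement of the fused core, so no single-point step between them can be drawn.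

Compound 3, `ClCc1ccc(Cn2cnc3ncnc(Cl)c32)cc1`, has not yet been measured in this assay. Compared with compound 1 it carries hydrogen in place of chloro on an aromatic carbon, that is, hydrogen in place of chloro on an aromatic carbon. Going by the values given here, no measured pair shows what this change does, so the size of the step is a matter of expectation only: loss of a chloro from the core of compound 1 is expected to give a somewhat higher number, but not far beyond the scatter. The step is estimated as a 2.0-fold higher number from compound 1 to compound 3 (0.29 log units; within the scatter). Compound 3 is therefore expected to give about 8000 nM, within a range from 2500 nM to 30000 nM.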

Compound 3, concentration for total growth inhibition: 4160 nM
Compound 3: middle estimate off by 1.9-fold (0.28 log units), on the high side; low and high end bracket the measured number.
By their numbers in this assay, from the lowest: compounds 1 and 3 (each within the scatter of the next); then compound 2.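

In this assay, for the compounds shown here, hydrogen in place of chloro on an aromatic carbon gives a 1.0-fold higher number from compound 1 to compound 3 (0.01 log units; within the scatter), the first reading of this change. At this carbon, which lies between two ring nitrogen atoms, the chloro group of compound 1 can therefore give way to hydrogen with no difference that the method can resolve, and the second chloro group, meta to this carbon, stays in place in both compounds. No measurement available here bears on why the exchange leaves the number within the scatter.

The compounds shown leave open what a larger or different group on this same carbon would do, such as an amine, a methoxy group or a longer chain, since chloro and hydrogen are the only two groups compared there. They also leave open what would follow from replacing the remaining chloro group, or the chloromethyl group on the benzyl arm, with hydrogen or an amine, as no pair among these compounds differs at either place.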